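Swapping the aryl group on a pyrazolopyridine kinase ligand

A few compounds are considered here, and "the series" means these few. Any claim that something is new, unique, unknown or untested is made for them only; others in the source may bear on it.

Compound 3 `CCCS(=O)(=O)Nc1ccc(F)c(C(=O)c2n[nH]c3ncc(-c4ccc(Cl)cc4Cl)cc23)c1F` gives 22% in an assay for binding affinity to dual specificity mitogen-activated protein kinase kinase 4 (Homo sapiens), read by KINOMEscan, tested at 100 nM (on this read-out higher numbers stand for a weaker effect at the one concentration tested and lower numbers for a stronger effect), the second highest of the three numbers. Compound 2 `CCCS(=O)(=O)Nc1ccc(F)c(C(=O)c2n[nH]c3ncc(-c4cccc(N(C)C)c4)cc23)c1F` gives 26%, and a number 4 percentage points lower from compound 2 to compound 3 (within the scatter). Compound 1 `CCCS(=O)(=O)Nc1ccc(F)c(C(=O)c2n[nH]c3ncc(-c4cccc(F)c4)cc23)c1F` gives 8.2%, and a number 13.8 percentage points higher from compound 1 to compound 3 (beyond the scatter). Compound 4 `CCCS(=O)(=O)Nc1ccc(F)c(C(=O)c2n[nH]c3ncc(-c4cccc(C(F)(F)F)c4)cc23)c1F` carries a different aryl group: 3-(trifluoromethyl)phenyl in place of 2,4-dichlorophenyl on an aromatic carbon. Of the measured steps, a number 4 percentage points lower from compound 2 to compound 3 (within the scatter) shows that exchanging one aryl group for another can leave the read-out unchanged, while a number 17.8 percentage points higher from compound 1 to compound 2 (beyond the scatter) and a number 13.8 percentage points higher from compound 1 to compound 3 (beyond the scatter) show modest moves either way. Going by the values given here, with no measured step involving this group, the author expects a small change, if any, in this assay, so a number 5 percentage points lower from compound 3 to compound 4 (within the scatter) is estimated. Compound 4 is expected to give 17%, within 6% to 34%.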

Compound 4, a percentage reported as activity, at one concentration (the size of the read-out at that concentration, not a potency): 57%
The estimate for compound 4 lay 40 percentage points below the measured number; measured number above the stated range.
By their numbers in this assay, from the lowest: compound 1; then compounds 3 and 2 (each within the scatter of the next); then compound 4.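

The aryl group on this aromatic carbon can shift this assay much further than the earlier modest steps suggested, with a number 35 percentage points higher from compound 3 to compound 4 (beyond the scatter) and a number 31 percentage points higher from compound 2 to compound 4 (beyond the scatter) and a number 48.8 percentage points higher from compound 1 to compound 4 (beyond the scatter) as the large steps. The trifluoromethyl group thus sets compound 4 apart from each of the fluoro, dimethylamino and 2,4-dichloro compounds, so changing the aryl substituent does not always leave this read-out within a narrow band. Nothing available bears on why this change has so large an effect. As far as these compounds go, whether a nitrile or a methoxy group on the same phenyl ring would give a number closer to compound 1 or to compound 4 remains open.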